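Acetoxy to ethoxy: working notes on compound 3

A few compounds are considered here, and "the series" means these few. Any claim that something is new, unique, unknown or untested is made for them only; others in the source may bear on it.

Of the compounds shown here, two have been measured so far. In a functional assay on SNO cells (Homo sapiens) for cytotoxicity, read by XTT assay, with a stated time of 24 h (on this read-out lower numbers stand for stronger inhibition and higher numbers for weaker inhibition), compound 1 (`CC(=O)Oc1cc(C)c(Cl)c2c1C(=O)C=CC2=O`) gives 28800 nM and compound 2 (`CC(=O)Oc1c(C)cc(Cl)c2c1C(=O)C=CC2=O`) gives 28600 nM on the same read-out. Within the data shown here, these two values lie within the scatter of each other, so compound 1 stands level with the only other measured compound, and neither can be ranked.

The next entry is compound 3 (`CCOc1cc(C)c(Cl)c2c1C(=O)C=CC2=O`), which has ethyl in place of acetyl on an oxygen on an aromatic ring, or acetoxy to ethoxy, on the core of compound 1 (ethyl in place of acetyl on an oxygen on an aromatic ring). Among the measured compounds shown here, no measured pair shows this exchange, so the size of its effect has no direct precedent here.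

The expectation therefore rests on the value of compound 1 at 28800 nM in this assay and allows for a shift in either direction. The estimated change is a 1.2-fold lower number from compound 1 to compound 3 (0.06 log units; within the scatter) and no step beyond the scatter is expected. For compound 3 the expected value is 25000 nM with an estimated range from 10000 nM to 60000 nM on this read-out.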

Compound 3, half-maximal inhibitory concentration: 44200 nM
Estimate against measurement, compound 3: 1.8-fold (0.25 log units) below; low and high end bracket the measured number.
By their numbers in this assay, from the lowest: compounds 2, 1 and 3 (each within the scatter of the next).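

In this assay, among these compounds, ethyl in place of acetyl on an oxygen on an aromatic ring gives a 1.5-fold higher number from compound 1 to compound 3 (0.19 log units; within the scatter), which provides the first direct reading of acetoxy to ethoxy. On the core of compound 1, the carbonyl of the acetyl group can therefore be removed from this oxygen, leaving ethyl, without a step beyond the usual scatter of this read-out. No measured evidence bearing on the cause of this result is available.

This single pair leaves open whether other groups on the same oxygen, such as a longer chain like butyl, a chain ending in an amine or one ending in a carboxylic acid, would give a step beyond the scatter. It also leaves open whether acetoxy to ethoxy on the core of compound 2 would give a step of similar size, and so whether this reading holds beyond the one core.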